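Swapping the Aryl Group on the Amine Arm for a Benzodioxin

The compounds below may be only part of what the source reports. "The series", "measured", "known", "first", "only" and "open" are said of these compounds alone.

The measured compounds so far:
compound 1, `O=S(=O)(NCCCNCc1ccccc1Cl)c1cc(C(F)(F)F)cc(C(F)(F)F)c1`, which in a functional assay on BXPC-3 cells (Homo sapiens) for inhibition, read by MTT assay, with a stated time of 72 h (a higher number here means a weaker inhibitor of growth, a lower number a stronger inhibitor of growth), gives 11000 nM
compound 2, `COc1ccc(CNCCCNS(=O)(=O)c2cc(C(F)(F)F)cc(C(F)(F)F)c2)cc1OC`, which in this assay gives 13000 nM

For the measured compounds named here, compound 2 holds the higher of the two numbers in this assay, but its only neighbour, compound 1, sits within the scatter of it, so the two cannot be ranked. Going by the values given here, the one step seen, a 1.2-fold higher number from compound 1 to compound 2 (0.07 log units; within the scatter), changes the aryl group on the amine arm and leaves the read-out essentially unmoved.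

Compound 3, `O=S(=O)(NCCCNCC1COc2ccccc2O1)c1cc(C(F)(F)F)cc(C(F)(F)F)c1`, differs from compound 2 by 2,3-dihydro-1,4-benzodioxin-2-yl in place of 3,4-dimethoxyphenyl on a saturated chain carbon bound to an amine nitrogen. Among the compounds with values here, this is again a change at the same place, and the only measured step there, from compound 1 to compound 2, was within the scatter. No other information bears on it, so no movement beyond the scatter is expected in this assay. Compound 3 is therefore estimated to give 12000 nM, with a range from 5000 nM to 30000 nM, which corresponds to an expected step of a 1.1-fold lower number from compound 2 to compound 3 (0.03 log units; within the scatter).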

Compound 3, concentration for 50% growth inhibition: 1200 nM
Compound 3: middle estimate off by 10-fold (1.00 log units), on the high side, outside the stated range (below it).
By their numbers in this assay, from the lowest: compound 3; then compounds 1 and 2 (each within the scatter of the next).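

The position on the amine arm turns out not to be as indifferent as the first two compounds suggested: in this assay, the benzodioxin group gives an 11-fold lower number from compound 2 to compound 3 (1.03 log units; beyond the scatter), and in place of 2-chlorophenyl it gives a 9.2-fold lower number from compound 1 to compound 3 (0.96 log units; beyond the scatter). The 3,4-dimethoxyphenyl that leaves and the group that enters have the same counts of heavy atoms, hydrogen-bond donors and hydrogen-bond acceptors, so those counts do not separate them; what does differ is the added six-membered non-aromatic ring. No measurement shown here accounts for the drop in the number.

On these data alone, it remains open whether the ring oxygens matter, which a 1,2,3,4-tetrahydronaphthalen-2-ylmethyl group, with carbon in their place, could test. As far as these compounds go, it is also open whether the benzodioxin group would keep this lower number on a longer chain.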